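Swapping methoxy for fluoro on compound 3

A few compounds are considered here, and "the series" means these few. Any claim that something is new, unique, unknown or untested is made for them only; others in the source may bear on it.

Values in a functional assay on MCF7 cells (Homo sapiens) for antiproliferative activity, read by sulforhodamine B assay, with a stated time of 48 h (a lower number here means a stronger inhibitor, a higher number a weaker inhibitor), follow.
Compound 1 `CN1CCN(c2ccc(S(=O)(=O)Oc3cccc(F)c3)cc2)C1=O` gives > 100000 nM as a limit of the assay, not a number.
Compound 2 `CCCN1CCN(c2ccc(S(=O)(=O)Oc3cccc(F)c3)cc2)C1=O` gives 24000 nM 
Compound 3 `CCCCN1CCN(c2ccc(S(=O)(=O)Oc3cccc(OC)c3)cc2)C1=O` gives 490 nM 

Compound 3 holds the lowest number of these, 490 nM, while compound 2 stands far higher at 24000 nM. Compound 4 `CCCCN1CCN(c2ccc(S(=O)(=O)Oc3cccc(F)c3)cc2)C1=O` keeps the chain of compound 3 but has fluoro in place of methoxy on an aromatic carbon. Going by the values given here, the only measured step, an at least 4.1-fold lower number from compound 1 to compound 2 (0.61 log units; beyond the scatter), changes the chain, so no measured step tests this swap directly. The fluoro-bearing compound 2 at 24000 nM suggests a higher number beyond the scatter, though its shorter chain may account for part of that gap. The expected step is a 6.1-fold higher number from compound 3 to compound 4 (0.79 log units; beyond the scatter). For compound 4 the estimated value is 3000 nM, expected to fall between 700 nM and 12000 nM.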

Compound 4, half-maximal inhibitory concentration: 310 nM
Estimate against measurement, compound 4: 9.7-fold (0.99 log units) above; the measured number lies below the stated range.
By their numbers in this assay, from the lowest: compounds 4 and 3 (each within the scatter of the next); then compound 2. At a limit, above all of these: compound 1.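

In this assay, fluoro in place of methoxy on the aromatic carbon gives a 1.6-fold lower number from compound 3 to compound 4 (0.20 log units; within the scatter), so with the butyl chain in place these two groups cannot be told apart. Among the fluoro compounds the chain carries the large change: methyl in place of hydrogen on the chain gives a 77-fold lower number from compound 2 to compound 4 (1.89 log units; beyond the scatter), and propyl in place of hydrogen gives an at least 320-fold lower number from compound 1 to compound 4 (2.50 log units; beyond the scatter). That last step starts from a limit of the assay, not a number: the limit of > 100000 nM in this assay, at which 1 of the 4 values shown sits.

Going by these compounds, whether an amine or a carboxylic acid on this aromatic carbon would fit as well as methoxy and fluoro stays open. So does whether a chain longer than butyl would lower the number further.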